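Acetylation of the lactone-ring hydroxyl across two cores

A few compounds are considered here, and "the series" means these few. Any claim that something is new, unique, unknown or untested is made for them only; others in the source may bear on it.

Of the compounds shown here, three have been measured in a functional assay on ASK cells (Rattus norvegicus) for cytotoxicity, read by sulforhodamine B assay; on this read-out lower numbers stand for an effect already at smaller amounts and higher numbers for an effect only at larger amounts of compound. Compound 1 `C=C1CC[C@@H]2[C@](C)(CO[Si](C)(C)C(C)(C)C)[C@H](OC(C)=O)CC[C@@]2(C)[C@@H]1C/C=C1/C(=O)OC[C@H]1OC(C)=O` gives 1.22 uM. Compound 3 `C=C1CC[C@@H]2[C@](C)(CO[Si](C)(C)C(C)(C)C)[C@H](OC(C)=O)CC[C@@]2(C)[C@@H]1C/C=C1/C(=O)OC[C@H]1O` gives 8.17 uM. Compound 2 `C=C1CC[C@@H]2[C@](C)(COC(C)=O)[C@H](O)CC[C@@]2(C)[C@@H]1C/C=C1/C(=O)OC[C@H]1O` gives 16.7 uM, the highest number among the three, a higher number than compound 3 and a higher number still than compound 1.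

One change is measured directly: acetyl in place of hydrogen on an oxygen on a saturated carbon
It produced a 6.7-fold lower number from compound 3 to compound 1 (0.83 log units; beyond the scatter).

Compound 4 `C=C1CC[C@@H]2[C@](C)(COC(C)=O)[C@H](O)CC[C@@]2(C)[C@@H]1C/C=C1/C(=O)OC[C@H]1OC(C)=O` has not yet been measured. It arises from compound 2 by the same change, acetyl in place of hydrogen on an oxygen on a saturated carbon
The place is described in the same words for both pairs, so this is the same change. The two cores, those of compound 2 and compound 3, differ elsewhere; the difference between the two cores is not broken down here.

On the assumption that the change carries over from one core to the other, a step of similar size is expected: a 4.8-fold lower number from compound 2 to compound 4 (0.68 log units; beyond the scatter) is estimated, resting on the measured step of a 6.7-fold lower number from compound 3 to compound 1 (0.83 log units; beyond the scatter) and on the starting value of compound 2 at 16.7 uM. Compound 4 is accordingly estimated at 3.5 uM, with a range from 1.2 uM to 10 uM.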

Compound 4, concentration for half-maximal effect: 16.3 uM
Compound 4: the middle estimate sits 4.7-fold (0.67 log units) below what was measured, and the stated range ends below it.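

In this assay, acetyl in place of hydrogen on an oxygen on a saturated carbon gives a 1.0-fold lower number from compound 2 to compound 4 (0.01 log units; within the scatter), so on this core the hydroxy to acetoxy exchange has no readable effect. The step therefore does not carry over in size from one core to the other: the same change on two cores in this assay, a 6.7-fold lower number (0.83 log units; beyond the scatter) from compound 3 to compound 1 and a 1.0-fold lower number (0.01 log units; within the scatter) from compound 2 to compound 4, 6.5-fold (0.82 log units) apart, beyond the scatter of two such steps. Among these compounds, this shows that the size of the step depends on the core in this pair of pairs, but not which of the differences between the two cores is responsible, since those differences are not broken down and only two cores are compared.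

The compounds shown leave open whether the step on any further core would resemble the one on compound 1's core or the one on compound 4's core, and a core differing from compound 2 in a single place would be needed to locate the dependence. They also leave open how a longer acyl chain such as butyryl, or a benzoyl ester, on the same oxygen would read out on either core.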